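Replacing the 2-methoxyphenyl group of compound 3

The compounds below may be only part of what the source reports. "The series", "measured", "known", "first", "only" and "open" are said of these compounds alone.

In a functional assay on A549 cells (Homo sapiens) for cytotoxicity, read by MTT assay, with a stated time of 72 h (a lower number here means a stronger inhibitor, a higher number a weaker inhibitor), three compounds sharing one core have been read. Compound 1 (`COc1ccc(/C=C2\CCC/C(=C\c3cccc(OC)c3OC)C2=O)c(OC)c1`) gives > 20000 nM as a limit and not a number. Compound 2 (`COc1ccc(/C=C2\CCC/C(=C\c3cccc(OC)c3OC)C2=O)cc1OC`) gives 14400 nM as a true number. Compound 3 (`COc1ccccc1/C=C1\CCC/C(=C\c2ccc(OC)c(OC)c2)C1=O`) gives > 20000 nM as a limit as well. Compound 3 thus has no number of its own and stands at the limit of > 20000 nM in this assay, at which 2 of the 3 values shown sit, with compound 1.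

Compound 4 (`COc1ccc(/C=C2\CCC/C(=C\c3ccc(Cl)c(Cl)c3)C2=O)cc1OC`) differs from compound 3 in one group (3,4-dichlorophenyl in place of 2-methoxyphenyl on a double-bonded chain carbon bound to a double-bonded ring carbon). A 3,4-dichlorophenyl takes the place of the 2-methoxyphenyl on a double-bonded chain carbon bound to a double-bonded ring carbon. For the measured compounds named here, only one measured step comes near this change, an at least 1.3-fold higher number from compound 2 to compound 3 (0.14 log units; that floor lies within the scatter) and it concerns a methoxy group, not chlorine. Going by the values given here, no compound read so far carries chlorine, so the expectation rests on little. Compound 2 at 14400 nM shows that this core can give a number, and a modest move toward a lower number is expected in this assay for the new group. The expected step is an at least 2.2-fold lower number from compound 3 to compound 4 (0.34 log units; beyond the scatter) and it remains uncertain. Compound 4 is estimated at 9000 nM with an expected range of 3500 nM to 20000 nM on repeated measurement.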

Compound 4, half-maximal inhibitory concentration: 6900 nM
Compound 4: middle estimate off by 1.3-fold (0.12 log units), on the high side, and the stated range covers the measured number.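

In this assay, a 3,4-dichlorophenyl in place of the 2-methoxyphenyl on a double-bonded chain carbon bound to a double-bonded ring carbon gives an at least 2.8-fold lower number from compound 3 to compound 4 (0.46 log units; beyond the scatter). For the compounds shown here, this is the first step that involves chlorine, and it shows that exchanging the whole group at this place can bring a compound from a limit to a true number. The real size of the step stays unknown and only its floor can be read, because compound 3 has a limit and not a number: the limit of > 20000 nM in this assay, at which 2 of the 4 values shown sit.

The compounds shown leave open whether a single chlorine, as in a 4-chlorophenyl, would give a similar step, or whether the step comes from losing the methoxy group. As far as these compounds go, how an amine or a carboxylic acid on this phenyl ring would read in this assay also remains open.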